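Notes on the ring-nitrogen substituent and functional response

This account rests on a few compounds, and the source may have more. Where it says the series, first, only, none or still open, it means among the compounds named here.

Among the measured compounds shown here, compound 2 `Nc1scc(CN2CCN(c3cc(F)ccc3F)CC2)c1C(=O)c1ccc(Cl)cc1` gives -80% in a functional assay on CHO cells with adenosine receptor A1 (Homo sapiens) as the target, read by cAMP accumulation and immunoassay, with a stated time of 6 min, tested at 10 uM (on this read-out higher numbers stand for a weaker effect at the one concentration tested and lower numbers for a stronger effect), the lowest of the two numbers so far; its nearest neighbour is compound 1 `Nc1scc(CN2CCN(c3cccnc3)CC2)c1C(=O)c1ccc(Cl)cc1`, which gives -23% in this assay. For the measured compounds named here, the one measured step, a number 57 percentage points lower from compound 1 to compound 2 (beyond the scatter), swaps one aromatic group for another on the ring nitrogen.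

Compound 3 `Nc1scc(CN2CCN(CCCc3ccc(Cl)cc3)CC2)c1C(=O)c1ccc(Cl)cc1` is not yet measured. Its change from compound 2 is 3-(4-chlorophenyl)propyl in place of 2,5-difluorophenyl on an amine nitrogen in a ring. Going by the values given here, the step from compound 1 to compound 2 bears on it only in that the same ring nitrogen is varied; it shows the read-out is sensitive to what sits there, but no measured step covers a chain-linked aromatic group at this place. The expected step of a number 25 percentage points higher from compound 2 to compound 3 (beyond the scatter) is therefore uncertain, taken as a moderate move toward weaker effect. Compound 3 is estimated at -55%, range -95% to -5%.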

Compound 3, a percentage reported as activity, at one concentration (the size of the read-out at that concentration, not a potency): -76%
Beside the measured number, compound 3's estimate is 21 percentage points above it; measured number inside the range.
By their numbers in this assay, from the lowest: compounds 2 and 3 (each within the scatter of the next); then compound 1.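

In this assay this ring nitrogen accepts a ring carried on a chain as well as a ring without one: 3-(4-chlorophenyl)propyl in place of 2,5-difluorophenyl gives a number 4 percentage points higher from compound 2 to compound 3 (within the scatter) and so no separation between the two groups. Against pyridin-3-yl the same chain-linked group gives a number 53 percentage points lower from compound 1 to compound 3 (beyond the scatter) as its step, so among the three compounds shown, compound 1 is the one that stands apart, and it does so against two quite different groups. Nothing measured here speaks to the reason for this result.

Open, on these data alone, is whether a benzyl group or a longer chain ending in the same 4-chlorophenyl stays with compound 2 and compound 3 in this assay at this nitrogen. Also open, as far as these compounds go, is whether plain phenyl falls with those two or with compound 1.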